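The source may report more compounds than this note shows. Statements on the series, on what has been measured and on what is new or still open speak of the compounds shown alone.

Measured so far: compound 1 `COc1ccc(-c2nc3ccccc3s2)cc1NC(=O)c1cnccc1Cl` gives 121 10^-6 cm/s in an ADME assay for permeability, using PAMPA; on this read-out lower numbers stand for lower permeability and higher numbers for higher permeability; compound 2 `O=C(Nc1cc(-c2nc3ccccc3s2)ccc1F)c1cnccc1Cl` gives 306 10^-6 cm/s; compound 3 `COc1ccc(-c2nc3ccccc3o2)cc1NC(=O)c1cnccc1Cl` gives 391 10^-6 cm/s.

Compound 4 `O=C(Nc1cc(-c2nc3ccccc3o2)ccc1F)c1cnccc1Cl` is not yet measured. It differs from compound 3 by fluoro in place of methoxy on an aromatic carbon. The same kind of change links compound 1 and compound 2, where it gave a 2.5-fold higher number from compound 1 to compound 2 (0.40 log units; beyond the scatter). The two cores differ by 1,3-benzoxazol-2-yl in place of 1,3-benzothiazol-2-yl on an aromatic carbon, a change that gave a 3.2-fold higher number from compound 1 to compound 3 (0.51 log units; beyond the scatter). Around the place of the change, the only difference is that the group para to it is a 1,3-benzothiazol-2-yl group in compound 1 and a 1,3-benzoxazol-2-yl group in compound 3, so the change is the same kind, not the same. For compound 4 a step of a 1.7-fold higher number from compound 3 to compound 4 (0.22 log units; within the scatter) in this assay is expected, because a 2.5-fold higher number from compound 1 to compound 2 (0.40 log units; beyond the scatter) shows what this kind of change did once. Compound 4 is estimated at 650 10^-6 cm/s, between 320 10^-6 cm/s and 1300 10^-6 cm/s.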

Compound 4, apparent permeability in the ADME assay: 258 10^-6 cm/s
The estimate for compound 4 lay 2.5-fold (0.40 log units) above the measured number; the whole stated range lies above it.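

In the ADME assay, fluoro in place of methoxy gave a 1.5-fold lower number from compound 3 to compound 4 (0.18 log units; within the scatter), so the rise seen on the core of compound 1 did not carry over to the core of compound 3, and the two results differ: the same change on two cores in the ADME assay, a 2.5-fold higher number (0.40 log units; beyond the scatter) from compound 1 to compound 2 and a 1.5-fold lower number (0.18 log units; within the scatter) from compound 3 to compound 4, 3.8-fold (0.58 log units) apart, beyond the scatter of two such steps. Among these compounds, this shows that a step seen on one core cannot simply be assumed on another, but with only two cores it does not show why they differ or what a third core would do. In a physicochemical assay for solubility, in phosphate buffer, measured as kinetic solubility, with a stated time of 18 h, at pH 7.4 (a higher number here means a more soluble compound, a lower number a less soluble compound), compound 3 gives 1680 nM and compound 4 gives 130 nM. On the core of compound 3, the same change also goes with a large drop in the physicochemical assay: the measured solubility of compound 3, 1680 nM, and of compound 4, 130 nM, a 13-fold lower number (1.11 log units; beyond the scatter).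

Still open, from the compounds shown here alone, is how an amine, a nitrile or a longer chain such as ethoxy would behave in place of the methoxy. Also open, going by these compounds, is whether the drop in the physicochemical assay would appear on the core of compound 1.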